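A few compounds are considered here, and "the series" means these few. Any claim that something is new, unique, unknown or untested is made for them only; others in the source may bear on it.

Compound 1 `O=C(O)Cc1sc(C(c2ccc(F)cc2)c2ccc(F)cc2)nc1-c1ccc(Cl)cc1`: 9.7 nM
Compound 2 `O=C(O)Cc1sc(C(c2ccc(F)cc2)c2ccc(F)cc2)nc1-c1ccccc1`: 16 nM
Compound 3 `CS(=O)(=O)Nc1cccc(-c2nc(C(c3ccc(F)cc3)c3ccc(F)cc3)sc2CC(=O)O)c1`: 40 nM

These three compounds share a core and were compared in an in vitro assay on HEK385-7 cells for displacement of a labelled ligand from prostaglandin D2 receptor 2 (Homo sapiens); on this read-out lower numbers stand for stronger inhibition and higher numbers for weaker inhibition. Compound 3 stands at the weak end of the set: its number is the highest of the three, and the steps of a 4.1-fold higher number from compound 1 to compound 3 (0.62 log units; beyond the scatter) and a 2.5-fold higher number from compound 2 to compound 3 (0.40 log units; beyond the scatter) both lie beyond the scatter, while the step of a 1.6-fold higher number from compound 1 to compound 2 (0.22 log units; within the scatter) does not. Compound 4 `O=C(O)Cc1sc(C(c2ccc(F)cc2)c2ccc(F)cc2)nc1-c1cn[nH]c1` has not yet been measured in this assay. It differs from compound 3 in one place: 1H-pyrazol-4-yl in place of 3-(methanesulfonamido)phenyl on an aromatic carbon. Going by the values given here, no measured step swaps a six-membered ring for a five-membered one at this position; the two steps that reach compound 3 show only that changing the group there moves the number modestly. The ring that enters is smaller than the one that leaves, yet it keeps a hydrogen-bond donor and an acceptor, as the leaving group does. Among the compounds with values here, with no closer precedent, the expected change is at most modest and could go either way. Compound 4 is therefore expected to give about 50 nM in this assay, with a range from 15 nM to 170 nM. That estimate means a step of a 1.3-fold higher number from compound 3 to compound 4 (0.10 log units; within the scatter), expected to stay within the scatter.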

Compound 4, half-maximal inhibitory concentration: 16 nM
Beside the measured number, compound 4's estimate is 3.1-fold (0.49 log units) above it, and the stated range covers the measured number.
By their numbers in this assay, from the lowest: compounds 1, 2 and 4 (each within the scatter of the next); then compound 3.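

A smaller five-membered ring can take this position on the shared core without a clear loss: in this assay, replacing phenyl with 1H-pyrazol-4-yl gives (no change at the digits printed from compound 2 to compound 4 (within the scatter)), and replacing 4-chlorophenyl with it gives (a 1.6-fold higher number from compound 1 to compound 4 (0.22 log units; within the scatter)). The earlier compounds shown here held only six-membered rings here, and the step from the larger 3-(methanesulfonamido)phenyl, with 11 heavy atoms, to the 5 heavy atoms of 1H-pyrazol-4-yl is (a 2.5-fold lower number from compound 3 to compound 4 (0.40 log units; beyond the scatter)), so the group with more heavy atoms goes with the higher number in this one comparison, and the presence of a hydrogen-bond donor and acceptor in both groups does not keep the number level. Nothing measured here explains why the number shifts in one comparison and holds in the others.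

The compounds shown leave open whether the hydrogen on the pyrazole nitrogen matters, which a 1-methyl-1H-pyrazol-4-yl group would test. They also leave open how a non-aromatic ring such as piperidin-4-yl, or a simple amine, would fare at this position.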